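Moving a Fluorine and Watching the Inhibition Hold

The source may hold more compounds than are shown below. What is called first, only, known or untested is meant among the compounds shown, and "the series" means these compounds.

Measured compounds in an assay on isolated protein for inhibition of Amine oxidase [flavin-containing] B (Homo sapiens), read by fluorescence, with a stated time of 1 h, tested at 10 uM; a higher number here means more inhibition at the concentration tested (going by the name of the read-out), a lower number less inhibition:
Compound 1, `c1ccc(-c2nc3ccc(N4CCCCCC4)nc3o2)cc1`, gives 57.9%.
Compound 2, `c1ccc(-c2nc3ccc(N4CCCCC4)nc3o2)cc1`, gives 86.8%.
Compound 3, `Fc1ccccc1-c1nc2ccc(N3CCCCC3)nc2o1`, gives 94.9%.

Compound 3 shows the highest number of the three; the value of compound 2 lies within the scatter of it, while compound 1 lies beyond the scatter below it. Compound 4, `Fc1cccc(-c2nc3ccc(N4CCCCC4)nc3o2)c1`, differs from compound 3 in one place: 3-fluorophenyl in place of 2-fluorophenyl on an aromatic carbon. Going by the values given here, only one measured step touches the fluorine-bearing ring, a number 8.1 percentage points higher from compound 2 to compound 3 (within the scatter), and it stayed within the scatter; the other, a number 28.9 percentage points higher from compound 1 to compound 2 (beyond the scatter), concerns a different part of the molecule. Among the compounds with values here, no measured step moves the fluorine around its ring. The expected step is therefore a number 4.9 percentage points lower from compound 3 to compound 4 (within the scatter), nothing beyond the scatter. Compound 4 is estimated at 90%, between 75% and 100%.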

Compound 4, a percentage reported as inhibition, at one concentration (the size of the read-out at that concentration, not a potency): 89.7%
Compound 4: the middle estimate sits 0.3 percentage points above what was measured; measured number inside the range.
By their numbers in this assay, from the lowest: compound 1; then compounds 2, 4 and 3 (each within the scatter of the next).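

Swapping 2-fluorophenyl for 3-fluorophenyl gives a number 5.2 percentage points lower from compound 3 to compound 4 (within the scatter) in this assay, so at this position the fluorine can sit at either of these two ring positions without a shift beyond the scatter. Fluoro in place of hydrogen at the new ring position gives a number 2.9 percentage points higher from compound 2 to compound 4 (within the scatter), so neither fluorinated compound separates from the unfluorinated compound 2. Nothing available here bears on why the reading holds.

From the compounds shown here alone, whether the number stays level with a methoxy group or a carboxylic acid on the same ring remains open. So does whether these compounds would differ in potency, since each reading comes from a single concentration.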